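A Cyclopropyl Analogue in a Pancreatic Cell Cytotoxicity Series

The compounds below may be only part of what the source reports. "The series", "measured", "known", "first", "only" and "open" are said of these compounds alone.

Measured so far:
Compound 1 `CCCCCc1cn(C(c2ccccc2)c2cc3cc(Br)ccc3nc2OC)nn1`: 5.07%
Compound 2 `COc1nc2ccc(Br)cc2cc1C(c1ccccc1)n1cc(-c2ccc(OC(F)(F)F)cc2)nn1`: 11.7%

Both numbers come from an ADME assay on PANC-1 cells (Homo sapiens) for cytotoxicity, read by sulforhodamine B assay, with a stated time of 48 h, tested at 10 uM; a higher number here means more inhibition at the concentration tested (going by the name of the read-out), a lower number less inhibition. Compound 2 stands highest of the two numbers shown, with compound 1 the nearest, and the step of a number 6.6 percentage points higher from compound 1 to compound 2 (within the scatter) lies within the scatter, so the two compounds cannot be told apart on this read-out; both sit at low inhibition at the concentration tested.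

Compound 3 `COc1nc2ccc(Br)cc2cc1C(c1ccccc1)n1cc(C2CC2)nn1` has not yet been measured in this assay. It differs from compound 2 in one place: cyclopropyl in place of 4-(trifluoromethoxy)phenyl on an aromatic carbon. Among the measured compounds shown here, the only measured step that bears on this change is a number 6.6 percentage points higher from compound 1 to compound 2 (within the scatter), which exchanged a chain for an aromatic ring on that same aromatic carbon and left the read-out within the scatter. Since neither of those two groups moved the number beyond the scatter, the step of a number 4.7 percentage points lower from compound 2 to compound 3 (within the scatter) is expected to stay within the scatter as well, with no clear direction. Compound 3 is therefore estimated at 7%, within a range of -6% to 20%.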

Compound 3, a percentage reported as inhibition, at one concentration (the size of the read-out at that concentration, not a potency): 21.8%
The estimate for compound 3 lay 14.8 percentage points below the measured number, outside the stated range (above it).
By their numbers in this assay, from the lowest: compounds 1 and 2 (each within the scatter of the next); then compound 3.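

In this assay, this position on the five-membered aromatic ring with 3 nitrogen turns out to respond to the group it carries: cyclopropyl in place of 4-(trifluoromethoxy)phenyl gives a number 10.1 percentage points higher from compound 2 to compound 3 (beyond the scatter), and cyclopropyl in place of pentyl gives a number 16.7 percentage points higher from compound 1 to compound 3 (beyond the scatter). Compounds 1 and 2 could not be told apart, so their pair gave no sign of this, whereas compound 3 now stands clear of both a compound with a chain and a compound with an aromatic ring at the same place, though both steps are modest. Nothing available explains why the small carbon ring goes with the higher number.

Among the compounds shown here, with only three groups compared, it remains open whether the three-membered ring itself matters or whether other small groups would do the same, which an isopropyl or a cyclobutyl group at this place could help to separate. As far as these compounds go, it is also open how this position would respond to a group carrying nitrogen or oxygen, such as an aminomethyl or a hydroxymethyl group.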